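Methyl on the phenyl ring of compound 3

The source may report more compounds than this note shows. Statements on the series, on what has been measured and on what is new or still open speak of the compounds shown alone.

In a functional assay on HT-1080 cells (Homo sapiens) for antiproliferative activity, read by MTT assay, with a stated time of 72 h (on this read-out higher numbers stand for weaker inhibition and lower numbers for stronger inhibition), compound 1 (`O=C1C=C(N2CCN(c3ccccc3Cl)CC2)C(=O)c2ccccc21`) gives 15400 nM, compound 2 (`Cc1ccccc1N1CCN(C2=CC(=O)c3cccc(O)c3C2=O)CC1`) gives 11000 nM and compound 3 (`O=C1C=C(N2CCC(c3ccccc3)CC2)C(=O)c2c(O)cccc21`) gives 11100 nM. Compound 3 stands within the scatter of both other compounds, so these three values set no order.

Compound 4 (`Cc1ccccc1C1CCN(C2=CC(=O)c3cccc(O)c3C2=O)CC1`) carries methyl in place of hydrogen on an aromatic carbon, ortho to a large group, turning phenyl to 2-methylphenyl: methyl in place of hydrogen on an aromatic carbon. Within the data shown here, no step between measured compounds is available to size this change. In this assay no step beyond the scatter is expected, in either direction, and the expectation rests on compound 3 at 11100 nM. Compound 4 is expected at 10500 nM, with an estimated range of 5000 nM to 21000 nM.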

Compound 4, half-maximal inhibitory concentration: > 50000 nM
Compound 4: a limit, no number; the forecaster's own chance of this, stated with the estimate: 4%; middle value at least 4.7-fold (0.67 log units) away from the limit.
By their numbers in this assay, from the lowest: compounds 2, 3 and 1 (each within the scatter of the next). At a limit, above all of these: compound 4.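

A single methyl on an aromatic carbon, ortho to a large group, is enough to shift the read-out in this assay: the change from phenyl to 2-methylphenyl gives an at least 4.5-fold higher number from compound 3 to compound 4 (0.65 log units; beyond the scatter). Compound 4 reads > 50000 nM, which is a limit of the assay and not a number, so the step has a lower bound only. Among these compounds, the earlier compounds offered no step, so this is the first sign that this position responds to substitution. Open, on these data alone, is whether fluoro, methoxy or an amine on the same carbon behaves like methyl. Also open, as far as these compounds go, is whether methyl elsewhere on the phenyl ring does the same.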